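Swapping the tetrazole substituent of compound 3 for a sulfonamidopentyl chain

This account rests on a few compounds, and the source may have more. Where it says the series, first, only, none or still open, it means among the compounds named here.

Compounds measured so far:
Compound 1 `CC(C)(N)C(=O)N[C@H](COCc1ccccc1)c1nnnn1Cc1ccc(NS(C)(=O)=O)cc1`: 259 nM
Compound 2 `CC(C)(N)C(=O)N[C@H](COCc1ccccc1)c1nnnn1CCCc1ccccc1`: 17 nM
Compound 3 `COC(=O)C(c1ccccc1)n1nnnc1[C@@H](COCc1ccccc1)NC(=O)C(C)(C)N`: 20 nM

All three share the same core and were tested in a functional assay on H4 cells for agonist activity at growth hormone secretagogue receptor type 1 (Homo sapiens), read by FLIPR; on this read-out higher numbers stand for an effect only at larger amounts of compound and lower numbers for an effect already at smaller amounts. Compound 1 sits apart, with a number well beyond the scatter above the other two. Compound 3 and compound 2 differ only within the scatter, so no order between them can be read; compound 3 stands far from compound 1, which gives a number beyond the scatter above it.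

Compound 4 `CC(C)(N)C(=O)N[C@H](COCc1ccccc1)c1nnnn1CCCCCNS(C)(=O)=O` is obtained from compound 3 by the change (5-(methanesulfonamido)pentyl in place of methoxycarbonyl)(benzyl on an aromatic nitrogen). Among the measured compounds shown here, two measured steps bear on it. The step of a 1.2-fold higher number from compound 2 to compound 3 (0.07 log units; within the scatter) shows that changing the group on the aromatic nitrogen between two aryl-containing groups cost nothing. The step of a 15-fold lower number from compound 1 to compound 2 (1.18 log units; beyond the scatter), in contrast, shows that the compound carrying a methanesulfonamido group on this substituent gave a much higher number than the one without it. Compound 4 again carries a methanesulfonamido group, now on a chain with no ring, and so a higher number than for compound 3 is expected, with the step of a 6.0-fold higher number from compound 3 to compound 4 (0.78 log units; beyond the scatter). Compound 4 is therefore estimated at 120 nM, within a range from 30 nM to 500 nM.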

Compound 4, half-maximal effective concentration: 75 nM
For compound 4 the middle estimate is 1.6-fold (0.20 log units) above the measured one; measured number inside the range.
By their numbers in this assay, from the lowest: compounds 2 and 3 (each within the scatter of the next); then compound 4; then compound 1.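

The four compounds now show that the methanesulfonamido group raises the number on a chain with no ring as well as on a ring-bearing substituent: in this assay there is a 3.8-fold higher number from compound 3 to compound 4 (0.57 log units; beyond the scatter) and a 4.4-fold higher number from compound 2 to compound 4 (0.64 log units; beyond the scatter), so the 5-(methanesulfonamido)pentyl group does not match the two groups without this function, both of which carry a six-membered aromatic ring. What carries the methanesulfonamido group also matters at this aromatic nitrogen, since the ring-free chain gives a 3.5-fold lower number from compound 1 to compound 4 (0.54 log units; beyond the scatter), so both compounds with this group stand above compounds 2 and 3, yet they remain clearly apart from each other. Nothing available explains these differences.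

The compounds shown leave open how much of the rise belongs to the methanesulfonamido group and how much to the loss of the aromatic ring, a question that a plain pentyl chain on the same nitrogen would separate. They also leave open whether a shorter or longer chain carrying the same group, or a pentyl chain ending in an amine or a carboxylic acid, would move the number further in either direction.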